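A Methyl Branch on Two Different Side Chains

The compounds below may be only part of what the source reports. "The series", "measured", "known", "first", "only" and "open" are said of these compounds alone.

Measured in an assay on membranes from CHO cells for displacement of a labelled ligand from adenosine receptor A1 (Homo sapiens), read by scintillation counting, with a stated time of 60 min, tested at 1 uM; a lower number here means less inhibition, a higher number more inhibition at the concentration tested (going by the name of the read-out):
compound 1 `CCCC(=O)C1=C(C)NC(=O)NC1c1ccco1`: 1%
compound 2 `CC1=C(C(=O)CC(C)C)C(c2ccco2)NC(=O)N1`: 16%
compound 3 `CCNC(=O)C1=C(C)NC(=O)NC1c1ccoc1`: 1%

Compound 1 and compound 3 sit together at the lowest of the three numbers, level at the digits printed, with no change between them at the digits printed. Compound 2 stands apart: the step of a number 15 percentage points higher from compound 1 to compound 2 (beyond the scatter) came with methyl in place of hydrogen on a saturated chain carbon bound to two saturated chain carbons. How the core of compound 1 differs from the core of compound 3 is not broken down here.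

Compound 4 `CC1=C(C(=O)NC(C)C)C(c2ccoc2)NC(=O)N1` differs from compound 3 by methyl in place of hydrogen on a saturated chain carbon bound to an amide-type nitrogen and a saturated chain carbon. This is the same kind of change as that from compound 1 to compound 2, though not the same: there the carbon was bound to two saturated chain carbons, here it is bound to an amide-type nitrogen and a saturated chain carbon. Because compound 3 gives 1%, a step of a number 11 percentage points higher from compound 3 to compound 4 (beyond the scatter) in this assay is expected, resting on the size of a number 15 percentage points higher from compound 1 to compound 2 (beyond the scatter) and tempered by the different surroundings of the new methyl. Compound 4 is therefore estimated at 12%, within 0% to 30%.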

Compound 4, a percentage reported as inhibition, at one concentration (the size of the read-out at that concentration, not a potency): 1%
The estimate for compound 4 lay 11 percentage points above the measured number; the measured number falls inside the stated range.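

In this assay, methyl in place of hydrogen on a saturated chain carbon bound to an amide-type nitrogen and a saturated chain carbon gave no change at the digits printed from compound 3 to compound 4 (within the scatter). Set beside the earlier step, this shows that the methyl branch did not carry the same result from one core to the other in this series: the same change on two cores in this assay, a number 15 percentage points higher (beyond the scatter) from compound 1 to compound 2 and no change at the digits printed (within the scatter) from compound 3 to compound 4, 15 percentage points apart, beyond the scatter of two such steps. It does not show which difference between the two compounds that received the methyl decides the outcome, whether the surroundings of the new methyl or another part of the core, and two pairs at one tested concentration support no general rule.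

The compounds shown leave open whether a longer chain or a carboxylic acid in place of the isopropyl of compound 4 would change the number. Also open, from the compounds shown here alone, is how the methyl branch behaves on a core that differs from that of compound 1 in one place only.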